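The source may report more compounds than this note shows. Statements on the series, on what has been measured and on what is new or still open speak of the compounds shown alone.

Compound 2 `COc1cc(-c2c(C#N)c(N)n(/N=C/c3cn(-c4ccccc4)nc3-c3ccccc3)c(=O)c2C#N)cc(OC)c1OC` gives 64 ug/mL in an ADME assay on NIH3T3 cells (Mus musculus) for cytotoxicity, read by MTT assay (on this read-out higher numbers stand for weaker inhibition and lower numbers for stronger inhibition), and compound 1 `N#Cc1c(-c2ccc(O)cc2)c(C#N)c(=O)n(/N=C/c2cn(-c3ccccc3)nc2-c2ccccc2)c1N` gives 110 ug/mL in this assay. These two numbers sit within the scatter of each other, as the step of a 1.7-fold lower number from compound 1 to compound 2 (0.24 log units; within the scatter) shows. Compound 3 `N#Cc1c(-c2ccccc2Br)c(C#N)c(=O)n(/N=C/c2cn(-c3ccccc3)nc2-c2ccccc2)c1N` differs from compound 2 by 2-bromophenyl in place of 3,4,5-trimethoxyphenyl on an aromatic carbon. Among the compounds with values here, the only measured step exchanges a group at this same place and stayed within the scatter, and no measured compound carries a bromine-bearing ring, so in this assay no step beyond the scatter is expected. Compound 3 is estimated at 80 ug/mL, within 35 ug/mL to 180 ug/mL, an expected step of a 1.3-fold higher number from compound 2 to compound 3 (0.10 log units; within the scatter).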

Compound 3, half-maximal inhibitory concentration: 174 ug/mL
The estimate for compound 3 lay 2.2-fold (0.34 log units) below the measured number; measured number inside the range.
By their numbers in this assay, from the lowest: compounds 2, 1 and 3 (each within the scatter of the next, the first and the last beyond it).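

In this assay, this position now shows a step beyond the scatter, though a modest one: 2-bromophenyl in place of 3,4,5-trimethoxyphenyl gives a 2.7-fold higher number from compound 2 to compound 3 (0.43 log units; beyond the scatter). The same group in place of 4-hydroxyphenyl gives a 1.6-fold higher number from compound 1 to compound 3 (0.20 log units; within the scatter), so the outcome of this change depends on which group leaves, and compound 1 cannot be separated from either of the other two. Nothing available explains the gap between compound 2 and compound 3. Still open, as far as these compounds go, is how a 4-bromophenyl group would compare with 2-bromophenyl at this position. Also open, from the compounds shown here alone, is whether a phenyl ring carrying an amine or a carboxylic acid would move the number further.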